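This account rests on a few compounds, and the source may have more. Where it says the series, first, only, none or still open, it means among the compounds named here.

Measured so far:
Compound 1 `O=C(NCCCNc1cc(-c2cn(-c3ccccc3)nc2-c2cccc(O)c2)ccn1)Nc1ccc(F)cc1`: 3040 nM
Compound 2 `O=C(NCCCNc1cc(-c2cn(-c3ccccc3)nc2-c2cccc(O)c2)ccn1)Nc1cccc(C(F)(F)F)c1`: 3850 nM

In a functional assay on SW-620 cells (Homo sapiens) for antiproliferative activity, read by sulforhodamine B assay, with a stated time of 48 h (a lower number here means a stronger inhibitor, a higher number a weaker inhibitor), compound 1 gives 3040 nM. For the measured compounds named here, its only measured neighbour, compound 2, gives 3850 nM, and the two lie within the usual scatter of each other.

Compound 3 `COc1cccc(-c2nn(-c3ccccc3)cc2-c2ccnc(NCCCNC(=O)Nc3ccc(F)cc3)c2)c1` has not yet been measured. It differs from compound 1 in one place: methyl in place of hydrogen on an oxygen on an aromatic ring. This is methyl in place of hydrogen on an oxygen on an aromatic ring, so 3-hydroxyphenyl becomes 3-methoxyphenyl.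

Going by the values given here, the one measured step, a 1.3-fold higher number from compound 1 to compound 2 (0.10 log units; within the scatter), lies at a different place and does not test this change. Among the compounds with values here, it shows only that one swap elsewhere stayed within the scatter. With no direct evidence, a small move towards a higher number is expected, though that direction is uncertain.

The estimate amounts to an expected 1.3-fold higher number from compound 1 to compound 3 (0.12 log units; within the scatter).

For compound 3 the estimated value is 4000 nM, with an expected range of 1500 nM to 10000 nM.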

Compound 3, half-maximal inhibitory concentration: 8020 nM
For compound 3 the middle estimate is 2.0-fold (0.30 log units) below the measured one; low and high end bracket the measured number.
By their numbers in this assay, from the lowest: compounds 1 and 2 (each within the scatter of the next); then compound 3.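

In this assay, replacing the hydroxy of the 3-hydroxyphenyl group with methoxy gives a 2.6-fold higher number from compound 1 to compound 3 (0.42 log units; beyond the scatter), a modest weakening beyond the scatter. For the compounds shown here, the earlier swap at the other end of the molecule, a 1.3-fold higher number from compound 1 to compound 2 (0.10 log units; within the scatter), stayed within the scatter, so this is the first sign that activity responds to a change at this oxygen, even one as small as adding a single methyl. Nothing measured here explains the weakening.

With only hydroxy and methoxy at this place, the compounds shown cannot separate the loss of the hydrogen from the arrival of the methyl. As far as these compounds go, an amine or an ethoxy group here could help tell these apart, and it also remains open whether methoxy has the same effect alongside the 3-(trifluoromethyl)phenyl group of compound 2.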